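The source may hold more compounds than are shown below. What is called first, only, known or untested is meant among the compounds shown, and "the series" means these compounds.

Measured so far:
compound 1, `C=CCn1c(=O)/c(=C\c2cccc(C)c2)[nH]c(=O)/c1=C\c1ccccc1OC`, which in a functional assay on K562 cells (Homo sapiens) for cytotoxicity, read by CCK-8 assay, with a stated time of 72 h (on this read-out higher numbers stand for weaker inhibition and lower numbers for stronger inhibition), gives 8800 nM
compound 2, `C=CCn1c(=O)/c(=C\c2cc(F)ccc2C)[nH]c(=O)/c1=C\c1ccccc1OC`, which in this assay gives 1800 nM
compound 3, `C=CCn1c(=O)/c(=C\c2ccccc2OC)[nH]c(=O)/c1=C\c1ccccc1OC`, which in this assay gives 7400 nM

Compound 1 stands highest of these three numbers. Its nearest neighbour is compound 3, and the step of a 1.2-fold lower number from compound 1 to compound 3 (0.08 log units; within the scatter) stays within the scatter; the furthest is compound 2, reached by a 4.9-fold lower number from compound 1 to compound 2 (0.69 log units; beyond the scatter), a step beyond the scatter. Compound 4, `C=CCn1c(=O)/c(=C\c2ccccc2F)[nH]c(=O)/c1=C\c1ccccc1OC`, has not yet been measured and differs from compound 1 in a single place: 2-fluorophenyl in place of 3-methylphenyl on a double-bonded chain carbon bound to an aromatic carbon. Going by the values given here, two measured steps bear on this change, both starting from the same 3-methylphenyl of compound 1. Replacing it with 2-methoxyphenyl moved the number by a 1.2-fold lower number from compound 1 to compound 3 (0.08 log units; within the scatter), which is nothing beyond the scatter, while replacing it with 5-fluoro-2-methylphenyl gave a 4.9-fold lower number from compound 1 to compound 2 (0.69 log units; beyond the scatter). The entering 2-fluorophenyl shares a fluorine with compound 2 and carries one small group, so a modest downward step, possibly no larger than the scatter, is expected. The estimated value for compound 4 is 4500 nM, with a range from 1800 nM to 11000 nM, which is expected to correspond to a 2.0-fold lower number from compound 1 to compound 4 (0.29 log units; within the scatter).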

Compound 4, half-maximal inhibitory concentration: 5600 nM
For compound 4 the middle estimate is 1.2-fold (0.09 log units) below the measured one; the measured number falls inside the stated range.
By their numbers in this assay, from the lowest: compound 2; then compounds 4, 3 and 1 (each within the scatter of the next).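

In this assay, 2-fluorophenyl in place of 3-methylphenyl on a double-bonded chain carbon bound to an aromatic carbon gives a 1.6-fold lower number from compound 1 to compound 4 (0.20 log units; within the scatter), and fluoro in place of methoxy on an aromatic carbon gives a 1.3-fold lower number from compound 3 to compound 4 (0.12 log units; within the scatter), so compound 1, compound 3 and compound 4 cannot be told apart at this position. A fluorine on the aromatic ring is thus not enough on its own to match compound 2, since 2-fluorophenyl in place of 5-fluoro-2-methylphenyl gives a 3.1-fold higher number from compound 2 to compound 4 (0.49 log units; beyond the scatter), and compound 2 remains the only one of the four that stands apart. Nothing shown offers a reason for these steps.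

On these data alone, it remains open whether the fluoro or the methyl of 5-fluoro-2-methylphenyl accounts for the position of compound 2, or whether the step needs both. As far as these compounds go, how an amine or a carboxylic acid on this aromatic ring would read in this assay also stays open.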